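Fluoro in place of tert-butyl on the shared core

The source may report more compounds than this note shows. Statements on the series, on what has been measured and on what is new or still open speak of the compounds shown alone.

Compound 2 `CC(C)(C)c1ccc(S(=O)(=O)CS(=O)(=O)C(F)(F)F)cc1` gives 2800000 nM in a functional assay (mitochondria, liver) with Rattus norvegicus as the target; on this read-out lower numbers stand for stronger inhibition and higher numbers for weaker inhibition; its partner compound 1 `O=S(=O)(CS(=O)(=O)C(F)(F)F)c1ccc(OC(F)(F)F)cc1` gives 2950000 nM, and the two numbers lie within the scatter of each other. Compound 3 `O=S(=O)(CS(=O)(=O)C(F)(F)F)c1ccc(F)cc1` differs from compound 2 by fluoro in place of tert-butyl on an aromatic carbon. For the measured compounds named here, the one step that bears on this change, a 1.1-fold lower number from compound 1 to compound 2 (0.02 log units; within the scatter), exchanged another group at the same place on the ring and left the number within the scatter. A step from compound 2 to compound 3 of about the same size, no further than the scatter, is therefore expected, as a 1.1-fold higher number from compound 2 to compound 3 (0.03 log units; within the scatter). Compound 3 is estimated at 3000000 nM, within 1000000 nM to 9000000 nM.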

Compound 3, half-maximal inhibitory concentration: 3150000 nM
Compound 3: middle estimate off by 1.1-fold (0.02 log units), on the low side; low and high end bracket the measured number.
By their numbers in this assay, from the lowest: compounds 2, 1 and 3 (each within the scatter of the next).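

With fluoro in place of tert-butyl, this assay shows a 1.1-fold higher number from compound 2 to compound 3 (0.05 log units; within the scatter), and with fluoro in place of trifluoromethoxy it shows a 1.1-fold higher number from compound 1 to compound 3 (0.03 log units; within the scatter). On this aromatic carbon, then, a group of 1 heavy atom and a group of 4 heavy atoms fall within the scatter of each other, and so do all three groups shown. Nothing available accounts for this result. From the compounds shown here alone, whether an amine or a carboxylic acid at this place would give a step beyond the scatter remains open. So does the effect of any change elsewhere on the shared core.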